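Adding a methyl to the benzyl ring of compound 3

The compounds below may be only part of what the source reports. "The series", "measured", "known", "first", "only" and "open" are said of these compounds alone.

Three close relatives share one core and differ only on the ring attached to the sulfur through a single carbon. Compound 1 `Cc1ccc(CSc2cc(Cl)c(C)cc2S(=O)(=O)/N=C(\N)n2nc(C)cc2-c2ccccc2)cc1` gives 0.176 h in an ADME assay on microsomes from liver (Homo sapiens) for metabolic stability, read by LC-MS, using NADPH, tested at 5 uM; on this read-out higher numbers stand for a longer-lived compound and lower numbers for a shorter-lived compound. Compound 2 `Cc1cc(-c2ccccc2)n(/C(N)=N/S(=O)(=O)c2cc(C)c(Cl)cc2SCc2cccc(C(F)(F)F)c2)n1` gives 0.169 h in this assay. Compound 3 `Cc1cc(-c2ccccc2)n(/C(N)=N/S(=O)(=O)c2cc(C)c(Cl)cc2SCc2ccccc2)n1` gives 0.0938 h in this assay. Compound 3 cannot be told apart from the other two, since a 1.9-fold lower number from compound 1 to compound 3 (0.27 log units; within the scatter) and a 1.8-fold lower number from compound 2 to compound 3 (0.26 log units; within the scatter) both sit inside the scatter, as does a 1.0-fold lower number from compound 1 to compound 2 (0.02 log units; within the scatter).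

Compound 4 `Cc1cc(-c2ccccc2)n(/C(N)=N/S(=O)(=O)c2cc(C)c(Cl)cc2SCc2ccccc2C)n1` has not been measured. It differs from compound 3 in one place: methyl in place of hydrogen on an aromatic carbon. The measured steps that bear on this are the two that also change a substituent on that same ring, the step from compound 1 to compound 3 and the step from compound 2 to compound 3; each stayed within the scatter. A similar outcome is therefore expected here, with no step beyond the scatter in either direction, which is what a 1.3-fold higher number from compound 3 to compound 4 (0.11 log units; within the scatter) means. Compound 4 is accordingly estimated at 0.12 h, with a range from 0.06 h to 0.25 h.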

Compound 4, half-life: 0.154 h
Compound 4: the middle estimate sits 1.3-fold (0.11 log units) below what was measured; the measured number falls inside the stated range.
By their numbers in this assay, from the lowest: compounds 3, 4, 2 and 1 (each within the scatter of the next).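

Among these compounds, the 2-methylbenzyl of compound 4 puts a methyl on an aromatic carbon ortho to a large group, a place that none of the earlier compounds changes, and in this assay this step stays within the scatter (a 1.6-fold higher number from compound 3 to compound 4 (0.22 log units; within the scatter)). Compound 4 also cannot be told apart from compound 2 with its 3-(trifluoromethyl)phenyl (a 1.1-fold lower number from compound 2 to compound 4 (0.04 log units; within the scatter)) or from compound 1 with its 4-methylphenyl (a 1.1-fold lower number from compound 1 to compound 4 (0.06 log units; within the scatter)), so a methyl at this new place fits the same flat picture as those two groups. Nothing available explains this flat picture.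

Still open, on these data alone, is whether any group on this ring can move the half-life beyond the scatter. A chlorine, a methoxy group, an amine or a carboxylic acid on the same carbon would test this more strongly than a methyl can.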